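The source may hold more compounds than are shown below. What is called first, only, known or untested is meant among the compounds shown, and "the series" means these compounds.

Of the compounds shown here, three of a shared core have been measured in a functional assay on CHO.K1 cells for antagonist activity at prostaglandin D2 receptor 2 (Homo sapiens), read by GTPgammaS binding, with a stated time of 1 h; on this read-out higher numbers stand for weaker inhibition and lower numbers for stronger inhibition. Compound 1 `Cc1c(Cc2ccccc2S(=O)(=O)c2ccccc2F)c2c(n1CC(=O)O)CCNC2=O` gives 3.6 nM, and compound 2 `Cc1c(Cc2ccccc2S(=O)(=O)c2ccc(F)cc2)c2c(n1CC(=O)O)CCNC2=O` gives 3.3 nM; the change a 1.1-fold lower number from compound 1 to compound 2 (0.04 log units; within the scatter) stays within the scatter. Compound 3 `CCS(=O)(=O)c1ccccc1Cc1c2c(n(CC(=O)O)c1C)CCNC2=O` gives 550 nM, the highest of the three numbers and the weakest inhibition, since both a 150-fold higher number from compound 1 to compound 3 (2.18 log units; beyond the scatter) and a 170-fold higher number from compound 2 to compound 3 (2.22 log units; beyond the scatter) lie far beyond the scatter. The unmeasured compound 4 `Cc1c(Cc2ccccc2C(O)c2ccccc2)c2c(n1CC(=O)O)CCNC2=O` carries hydroxy(phenyl)methyl in place of ethylsulfonyl on an aromatic carbon. The two large steps into compound 3 both followed the loss of an aryl group at that position; compound 4 brings an aryl group back, though without the sulfonyl, so a large decrease in the number is expected, estimated as a 22-fold lower number from compound 3 to compound 4 (1.34 log units; beyond the scatter). Compound 4 is expected to give about 25 nM, within 5 nM to 150 nM.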

Compound 4, half-maximal inhibitory concentration: 32 nM
The estimate for compound 4 lay 1.3-fold (0.11 log units) below the measured number; the range from low to high includes it.
By their numbers in this assay, from the lowest: compounds 2 and 1 (each within the scatter of the next); then compound 4; then compound 3.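

In this assay, an aryl group on this aromatic carbon recovers much of the number without any sulfonyl (a 17-fold lower number from compound 3 to compound 4 (1.24 log units; beyond the scatter)). The hydroxy(phenyl)methyl group still falls short of both fluorophenylsulfonyl groups (a 9.7-fold higher number from compound 2 to compound 4 (0.99 log units; beyond the scatter); an 8.9-fold higher number from compound 1 to compound 4 (0.95 log units; beyond the scatter)), so an aryl group alone does not reach the level of compound 1 and compound 2. Nothing at hand gives a cause for these steps. The group on compound 4 differs from those on compound 1 and compound 2 in both the fluorine and the link. Phenylsulfonyl and benzoyl groups at this place could separate these two changes.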